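The source may hold more compounds than are shown below. What is called first, only, known or untested is meant among the compounds shown, and "the series" means these compounds.

Measured so far in a functional assay on MCF7 cells (Homo sapiens) for antiproliferative activity; a higher number here means a weaker inhibitor of growth, a lower number a stronger inhibitor of growth

compound 1 `Oc1ccc(-c2nc3ccccc3s2)cc1O` gives 2190 nM
compound 2 `COc1ccc(-c2nc3ccccc3s2)cc1OC` gives 52700 nM
compound 3 `COc1ccc(-c2nc3cc(F)ccc3s2)cc1Cl` gives 760 nM

Of these three, compound 3 (at 760 nM) has the lowest number and so is the strongest inhibitor of growth, with its gaps to compound 1 and compound 2 both beyond the scatter. The next compound, compound 4 `CCOc1cc(-c2nc3cc(F)ccc3s2)ccc1OC`, has not yet been measured. It carries ethoxy in place of chloro on an aromatic carbon, ortho to a methoxy group and meta to a large group (ethoxy in place of chloro on an aromatic carbon).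

Going by the values given here, no two measured compounds differ in one place only, so no direct step shows what this exchange does. The closest guide is compound 2 (at 52700 nM), which also has no chloro and carries two methoxy groups, yet it differs from compound 4 elsewhere as well. Three compounds cannot establish a pattern, so the expectation is loose: a clear move towards weaker growth inhibition, beyond the scatter, but probably not all the way to the number of compound 2. The expected change is a 5.3-fold higher number from compound 3 to compound 4 (0.72 log units; beyond the scatter) in this assay and carries wide uncertainty. For compound 4 the estimated value is 4000 nM, with an expected range from 500 nM to 30000 nM.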

Compound 4, concentration for 50% growth inhibition: 80 nM
Beside the measured number, compound 4's estimate is 50-fold (1.70 log units) above it; the whole stated range lies above it.
By their numbers in this assay, from the lowest: compound 4; then compound 3; then compound 1; then compound 2.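

In this assay, putting ethoxy in place of chloro on this aromatic carbon, ortho to a methoxy group and meta to a large group, gives a 9.5-fold lower number from compound 3 to compound 4 (0.98 log units; beyond the scatter), the first direct reading of a single change among these compounds. It shows that this position tolerates a group of three heavy atoms in place of a single chlorine, and that the exchange, which also adds one hydrogen-bond acceptor, goes with stronger growth inhibition rather than weaker. No measurement at hand explains this gain, so the step stands as an observation only.

The compounds shown leave open whether the gain follows from the oxygen attached to this carbon or from the chain carried on it, a question that a methoxy group, a longer chain such as propoxy, or an amine at the same carbon could help to separate. They also leave open whether the same exchange would give a step of similar size in a compound without the fluoro group, as this single pair speaks only for its own shared core.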